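The source may hold more compounds than are shown below. What is called first, only, known or untested is meant among the compounds shown, and "the series" means these compounds.

Working notes on the series in an ADME assay on MT4 cells (Homo sapiens) for cytotoxicity, read by MTT assay, with a stated time of 5 days; on this read-out lower numbers stand for higher toxicity in this test and higher numbers for lower toxicity in this test. Compound 1 `COc1cc2cc(C#N)ccc2c(OC)c1Oc1cc(NC(C)(C)C)nc(Nc2ccc(C#N)cc2)n1` reaches only the limit of the assay, > 125000 nM. Compound 2 `CCCC(CCC)Nc1cc(Oc2c(OC)cc3cc(C#N)ccc3c2OC)nc(Nc2ccc(C#N)cc2)n1` likewise gives a limit, > 125000 nM. Compound 3 `COc1cc2cc(C#N)ccc2c(OC)c1Oc1cc(NCC2CC2)nc(Nc2ccc(C#N)cc2)n1` also gives a limit, > 125000 nM. The steps a step that the two limits leave unreadable from compound 1 to compound 2, a step that the two limits leave unreadable from compound 1 to compound 3 and a step that the two limits leave unreadable from compound 2 to compound 3 are therefore not readable in size, since (the limit of > 125000 nM in this assay, at which 3 of the 3 values shown sit). Compound 2 stands at that limit together with the other two. Compound 4 `COc1cc2cc(C#N)ccc2c(OC)c1Oc1cc(NCCCO)nc(Nc2ccc(C#N)cc2)n1` differs from compound 2 by 3-hydroxypropyl in place of 1-propylbutyl on a nitrogen on an aromatic ring. For the measured compounds named here, no measured step bears on this change with a readable size; every change of the group on that nitrogen so far has left the read-out at the limit. The step that the limit leaves unreadable from compound 2 to compound 4 is therefore expected to be none beyond the scatter. Compound 4 is estimated at 150000 nM, within 70000 nM to 400000 nM, most likely again only a limit.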

Compound 4, half-maximal cytotoxic concentration: 23500 nM
Compound 4: middle estimate off by 6.4-fold (0.81 log units), on the high side; measured number outside the range, below it.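

In this assay the group on a nitrogen on an aromatic ring can move the read-out towards higher toxicity in this test: 3-hydroxypropyl in place of 1-propylbutyl gives an at least 5.3-fold lower number from compound 2 to compound 4 (0.72 log units; beyond the scatter) and the comparisons with the other two groups agree, with an at least 5.3-fold lower number from compound 1 to compound 4 (0.72 log units; beyond the scatter) and an at least 5.3-fold lower number from compound 3 to compound 4 (0.72 log units; beyond the scatter) as well. Each of these sizes is only a lower bound, and the steps among compound 1, compound 2 and compound 3 cannot be read: the limit of > 125000 nM in this assay, at which 3 of the 4 values shown sit.

As far as these compounds go, compound 4 differs from compound 2 in both chain size and the hydroxyl, so which of the two matters stays open. A plain propyl or a 3-methoxypropyl group on that nitrogen would separate them.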